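A few compounds are considered here, and "the series" means these few. Any claim that something is new, unique, unknown or untested is made for them only; others in the source may bear on it.

Compound 1 `COc1cccc(OC)c1OCCNCCOc1ccccc1OCc1ccc(Cl)cc1`, compound 2 `COc1cccc(OC)c1OCCNCCOc1ccccc1OCc1ccc(C)cc1` and compound 3 `COc1ccc(COc2ccccc2OCCNCCOc2c(OC)cccc2OC)cc1` share one core and differ only in a single group on an outer aromatic ring. In a functional assay on Vas deferens for antagonist activity at Alpha-1A adrenergic receptor (Rattus norvegicus) (a lower number here means a less potent compound, a higher number a more potent compound, by a factor of ten per unit of this negative logarithm), compound 1 gives 8.17, compound 2 gives 8.23 and compound 3 gives 8.54. Compound 2 thus stands second highest of the three: the step of a number 0.06 log units higher from compound 1 to compound 2 (within the scatter) lies within the scatter, whereas a number 0.31 log units higher from compound 2 to compound 3 (beyond the scatter) and a number 0.37 log units higher from compound 1 to compound 3 (beyond the scatter) lie beyond it. Compound 4 `CCOc1ccc(COc2ccccc2OCCNCCOc2c(OC)cccc2OC)cc1` awaits measurement in this assay. Compared with compound 2 the change is ethoxy in place of methyl on an aromatic carbon. The step that bears on this is a number 0.31 log units higher from compound 2 to compound 3 (beyond the scatter), where methyl also gave way to an oxygen-bearing group, so a modest rise is expected. Compound 4 is therefore expected to give 8.45, between 8.1 and 8.8. The expected step is a number 0.22 log units higher from compound 2 to compound 4 (within the scatter).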

Compound 4, negative logarithm of the antagonist equilibrium constant: 8.5
Beside the measured number, compound 4's estimate is 0.05 log units below it, within the range that was stated.
By their numbers in this assay, from the lowest: compounds 1, 2, 4 and 3 (each within the scatter of the next, the first and the last beyond it).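

With a number 0.04 log units lower from compound 3 to compound 4 (within the scatter) as the step in this assay as the measure, methoxy and ethoxy cannot be told apart at this position on the outer ring. Ethoxy stands clear of chloro, with a number 0.33 log units higher from compound 1 to compound 4 (beyond the scatter) as its step, but not of methyl, with a number 0.27 log units higher from compound 2 to compound 4 (within the scatter) as its step, although methoxy stood clear of both. No other measurement bears on these numbers, so what lies behind them stays unknown. Still open, on these data alone, is how a longer chain such as propoxy would compare with ethoxy here. Also open, as far as these compounds go, is what an amine or a carboxylic acid would do at this position.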